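A few compounds are considered here, and "the series" means these few. Any claim that something is new, unique, unknown or untested is made for them only; others in the source may bear on it.

Within the data shown here, in a functional assay (muscle tissue) with Cavia porcellus as the target (a lower number here means that less compound is needed, a higher number that more compound is needed for the effect), compound 1 `COC(=O)C1=C(C)N=C(C)/C(=C(\O)OC)C1c1cc(Cl)cc(Cl)c1` gives 93.3 nM and compound 2 `COC(=O)C1=C(C)N=C(C)/C(=C(\O)OC)C1c1ccccc1F` gives 42.7 nM, so compound 2 holds the lower of the two numbers so far. Among the measured compounds shown here, only one measured step bears on what comes next: a 2.2-fold lower number from compound 1 to compound 2 (0.34 log units; beyond the scatter). It changes the same group on the shared core that changes now. Compound 3 `COC(=O)C1=C(C)N=C(C)/C(=C(\O)OC)C1c1cccc(C)c1` has 3-methylphenyl in place of 2-fluorophenyl on a saturated ring carbon. For the measured compounds named here, no measured compound carries 3-methylphenyl, so a single modest step is a thin guide. Going by the values given here, compound 2 is the only compound with 2-fluorophenyl, and the one other group measured at this place, in compound 1, gave a higher number at 93.3 nM. A modest move towards a higher number therefore seems most likely, although it may stay small. The estimated step is a 1.8-fold higher number from compound 2 to compound 3 (0.24 log units; within the scatter). Compound 3 is expected at 75 nM, with an estimated range of 25 nM to 230 nM.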

Compound 3, half-maximal effective concentration: 110 nM
For compound 3 the middle estimate is 1.5-fold (0.17 log units) below the measured one, and the stated range covers the measured number.
By their numbers in this assay, from the lowest: compound 2; then compounds 1 and 3 (each within the scatter of the next).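

In this assay, the change to 3-methylphenyl gives a 2.6-fold higher number from compound 2 to compound 3 (0.41 log units; beyond the scatter), a second step at this position that lies beyond the scatter. The step of a 1.2-fold higher number from compound 1 to compound 3 (0.07 log units; within the scatter) stays within the scatter, so 3-methylphenyl and 3,5-dichlorophenyl cannot be told apart here, even though they differ in the atoms they carry, and of the three groups only 2-fluorophenyl stands apart, with the lowest number. Nothing measured on these compounds accounts for that difference.

The three compounds do not show whether the lower number of compound 2 goes with the fluorine itself or with where it sits on the phenyl ring, a question that 3-fluorophenyl and 2-methylphenyl at this position could help to settle. From the compounds shown here alone, how a phenyl ring bearing an amine or a carboxylic acid would behave here also remains open.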